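Replacing an aminophenyl with a dichlorophenyl on the shared core

A few compounds are considered here, and "the series" means these few. Any claim that something is new, unique, unknown or untested is made for them only; others in the source may bear on it.

Of the compounds shown here, three sharing one core have been measured in a functional assay (muscle tissue) with Cavia porcellus as the target; on this read-out lower numbers stand for an effect already at smaller amounts and higher numbers for an effect only at larger amounts of compound. Compound 1 `COC(=O)C1=C(C)N=C(C)/C(=C(\O)OC)C1c1ccccc1N` gives 39800 nM, the highest of the three numbers. Compound 2 `COC(=O)C1=C(C)N=C(C)/C(=C(\O)OC)C1c1cc([N+](=O)[O-])ccc1Cl` gives 30.2 nM, and compound 3 `COC(=O)C1=C(C)N=C(C)/C(=C(\O)OC)C1c1cc([N+](=O)[O-])ccc1O` gives 100 nM. Compound 1 thus sits far from both: its number lies well above that of compound 3 and further still above that of compound 2, both gaps well beyond the scatter.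

Compound 4 `COC(=O)C1=C(C)N=C(C)/C(=C(\O)OC)C1c1c(Cl)cccc1Cl` has not yet been measured. It differs from compound 1 in one place: 2,6-dichlorophenyl in place of 2-aminophenyl on a saturated ring carbon. Among the measured compounds shown here, no measured pair shows exactly this exchange. For the measured compounds named here, the one step that touches a related change is a 3.3-fold higher number from compound 2 to compound 3 (0.52 log units; beyond the scatter), where a chloro on the aromatic ring was swapped for a hydroxy; the compound with the chloro gave the lower number. Beyond that, the numbers show that both compounds carrying halogen or nitro substituents on the aromatic ring lie far below compound 1, which carries an amino group there.

On this basis a large downward step is expected: a 660-fold lower number from compound 1 to compound 4 (2.82 log units; beyond the scatter). Compound 4 is estimated at 60 nM in this assay, with a range from 10 nM to 400 nM.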

Compound 4, half-maximal effective concentration: 1.91 nM
Beside the measured number, compound 4's estimate is 31-fold (1.50 log units) above it, outside the stated range (below it).
By their numbers in this assay, from the lowest: compound 4; then compound 2; then compound 3; then compound 1.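

In this assay, putting 2,6-dichlorophenyl in place of 2-aminophenyl on the saturated ring carbon gives a 21000-fold lower number from compound 1 to compound 4 (4.32 log units; beyond the scatter), a large step well beyond the scatter, while the rest of the shared core stays the same. Among the compounds shown here, the earlier compounds showed only that a single exchange on the aromatic ring can shift the number modestly, as in a 3.3-fold higher number from compound 2 to compound 3 (0.52 log units; beyond the scatter); the new step shows that the choice of the whole aromatic group at this place can decide between an effect at very small amounts and one only at very large amounts. The exchange changes several things at once, since the amino group leaves and two chlorines enter, and nothing measured here says which of these matters or why the number moves so far.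

Left open is how the step divides between losing the amino group and gaining the chlorines: a plain phenyl or a 2-chlorophenyl at this place would separate the two. Also open, from the compounds shown here alone, is whether 2,6-dimethylphenyl, with methyl groups where compound 4 carries chlorines, would give a number close to that of compound 4.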